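This account rests on a few compounds, and the source may have more. Where it says the series, first, only, none or still open, it means among the compounds named here.

Measured so far:
compound 1, `CCN1C(=O)CN(Cc2ccc(-c3ccc(F)c(CN4CCCCC4)n3)cc2)C1=O`: 1.45 h
compound 2, `CC(C)CN1C(=O)CN(Cc2ccc(-c3ccc(F)c(CN4CCCC(C)C4)n3)cc2)C1=O`: 0.1 h

In an in vitro ADME assay on microsomes from liver (Homo sapiens) for metabolic stability, read by LC-MS, using NADPH, tested at 1 uM (a lower number here means that the compound disappears faster, a higher number that the compound lasts longer), compound 1 gives 1.45 h, while compound 2 gives 0.1 h. Compound 2 therefore stands lowest of the two numbers, and its gap to compound 1 lies well beyond the scatter of repeated measurements. The two compounds differ in more than one place, so no single change can be tied to that gap.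

Compound 3, `CC(C)CN1C(=O)CN(Cc2ccc(-c3ccc(F)c(CN4CCCCC4)n3)cc2)C1=O`, is not yet measured. It differs from compound 2 by hydrogen in place of methyl on a saturated ring carbon: 3-methylpiperidin-1-yl becomes piperidin-1-yl, everything else unchanged. For the measured compounds named here, there is no measured pair that isolates this change. Since the remaining difference from compound 1 is on the opposite end of the shared core, compound 3 is expected to land between the two measured numbers, and the step from compound 2 is estimated as an increase of a size that may only just exceed the scatter: a 3.0-fold higher number from compound 2 to compound 3 (0.48 log units; beyond the scatter). For compound 3 the expected value in this assay is 0.3 h, with a range of 0.1 h to 1.2 h.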

Compound 3, half-life in the Homo sapiens assay: 0.217 h
Estimate against measurement, compound 3: 1.4-fold (0.14 log units) above; measured number inside the range.
By their numbers in the Homo sapiens assay, from the lowest: compound 2; then compound 3; then compound 1.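

In the Homo sapiens assay, hydrogen in place of methyl on the saturated ring carbon, two ring bonds from the ring nitrogen, gives a 2.2-fold higher number from compound 2 to compound 3 (0.34 log units; beyond the scatter), the first read of 3-methylpiperidin-1-yl to piperidin-1-yl on its own, while isopropyl in place of methyl on the saturated chain carbon at the other end of the shared core gives a 6.7-fold lower number from compound 1 to compound 3 (0.82 log units; beyond the scatter), the larger of the two steps, so both places contribute to the gap that compound 1 and compound 2 left unassigned. In a physicochemical assay for acid dissociation, compound 2 gives 8.4 and compound 3 gives 8.6, and the step reads a number 0.20 log units higher from compound 2 to compound 3 (within the scatter), so the ring methyl leaves this read-out within the scatter while the half-life step lies beyond it. Nothing at hand gives a cause for either half-life step.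

From the compounds shown here alone, whether the ring methyl step holds at the same size on the end carried by compound 1 stays open, as does the outcome of a hydroxyl or a fluorine on that ring carbon. Going by these compounds, a cyclopropyl or a longer chain in place of the isopropyl on the chain carbon is equally open in both read-outs.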